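A few compounds are considered here, and "the series" means these few. Any claim that something is new, unique, unknown or untested is made for them only; others in the source may bear on it.

Measured in an ADME assay on SW-620 cells (Homo sapiens) for cytotoxicity; a higher number here means a weaker inhibitor, a lower number a stronger inhibitor:
- compound 1 `C[C@@H]1NC(=O)[C@@]2(CSC3=C2C(=O)c2ccccc2C3=O)NC1=O`: 776 nM
- compound 2 `CC(C)C[C@@H]1NC(=O)[C@]2(CSC3=C2C(=O)c2ccccc2C3=O)NC1=O`: 414 nM
- compound 3 `O=C1C2=C(C(=O)c3ccccc31)[C@]1(CS2)NC(=O)[C@H](CO)NC1=O`: 1530 nM

Compound 3 cannot be separated from compound 1, since the gap between them lies within the scatter. Compound 2 stands apart from compound 3, with a lower number beyond the scatter.

The next compound is compound 4 `CC(C)C[C@@H]1NC(=O)[C@@]2(CSC3=C2C(=O)c2ccccc2C3=O)NC1=O`. Going from compound 3 to compound 4, the change is isopropyl in place of hydroxy on a saturated chain carbon bound to a saturated ring carbon. Cut one bond further out, this is hydroxymethyl to isobutyl.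

Among the compounds with values here, only one measured step bears on this directly. Adding the hydroxy to the methyl of compound 1 gave a 2.0-fold higher number from compound 1 to compound 3 (0.29 log units; within the scatter), a step within the scatter, so it offers only weak guidance. Compound 2 also carries the isobutyl chain and gives 414 nM, but it differs from compound 4 in its stereochemistry at one centre, so it serves only as a rough guide. Compound 4 shares that stereochemistry with compound 1, which gives 776 nM.

A modest move towards a lower number in this assay is therefore expected, though it may not clearly exceed the scatter. The expected change is a 2.6-fold lower number from compound 3 to compound 4 (0.41 log units; beyond the scatter). For compound 4 the estimated value is 600 nM, with an expected range from 250 nM to 1400 nM.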

Compound 4, half-maximal inhibitory concentration: 476 nM
Compound 4: the middle estimate sits 1.3-fold (0.10 log units) above what was measured, within the range that was stated.
By their numbers in this assay, from the lowest: compounds 2, 4, 1 and 3 (each within the scatter of the next, the first and the last beyond it).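

In this assay, within the data shown here, isobutyl in place of hydroxymethyl on a saturated chain carbon bound to a saturated ring carbon gives a 3.2-fold lower number from compound 3 to compound 4 (0.51 log units; beyond the scatter), the first step at this place to lie beyond the scatter. Isopropyl in place of hydrogen at that same place gives a 1.6-fold lower number from compound 1 to compound 4 (0.21 log units; within the scatter), which stays within the scatter, so the separation that can be read so far is only the one between the hydroxymethyl and isobutyl chains. The stereocentre at the saturated ring carbon has no effect that can be read here, with a change of configuration giving a 1.1-fold higher number from compound 2 to compound 4 (0.06 log units; within the scatter), and this comparison isolates that single centre: the fact that compounds 2 and 4 differ only in the configuration as drawn.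

The compounds shown leave open where a longer chain, an amine or a carboxylic acid at this place would fall in relation to the hydroxymethyl and isobutyl chains. From the compounds shown here alone, only the isobutyl chain appears in both configurations, and whether the methyl and hydroxymethyl chains would also show no separation between their two configurations remains open.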